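The compounds below may be only part of what the source reports. "The series", "measured", "known", "first", "only" and "open" are said of these compounds alone.

Measured compounds:
compound 1 `CCC1(CCCCN2CCN(c3cccc(Cl)c3)CC2)C(=O)Nc2ccccc21` — > 10 mg/kg
compound 2 `CCC1(CCCCN2CCN(c3cccc(Cl)c3)CC2)C(=O)Nc2cc(F)c(Cl)cc21` — "not determined" (no result reported)
compound 3 `CCC1(CCCCN2CCN(c3ccc(F)cc3)CC2)C(=O)Nc2ccccc21` — not yet measured

In a functional assay on the whole organism (strain NMRI) with Mus musculus as the target, in the forced swim test, with stated times of 30 min, 4 min and 6 min (on this read-out higher numbers stand for an effect only at larger amounts of compound and lower numbers for an effect already at smaller amounts), compound 1 gives > 10 mg/kg, which is a limit of the assay and not a number. Compound 2 has no result in this assay. For the measured compounds named here, compound 1 therefore stands on a limit alone, as the single entry with a value, and the numbers show only (the limit of > 10 mg/kg in this assay, at which 1 of the 2 values shown sits). Compound 3 differs from compound 1 by 4-fluorophenyl in place of 3-chlorophenyl on an amine nitrogen in a ring. Going by the values given here, with no measured step between two compounds in this assay, the size of the change cannot be read from the data, and no direction beyond the scatter is expected. Compound 3 is expected to give about 10 mg/kg, within 3 mg/kg to 30 mg/kg. The estimated step of a number no higher from compound 1 to compound 3 (the limit leaves the size open) is expected to remain near the limit of compound 1, with a real chance that only a limit is again reported.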

Compound 3, minimum effective dose: > 10 mg/kg
Compound 3: a limit, no number; the forecaster's own chance of this, stated with the estimate: 65%; the middle value lies on the limit itself.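

In this assay compound 1 and compound 3 both rest on a limit of the assay and not on a number, so no step from one to the other can be read: the limit of > 10 mg/kg in this assay, at which 2 of the 3 values shown sit.

The compounds shown leave open whether 4-fluorophenyl in place of 3-chlorophenyl on an amine nitrogen in a ring changes the minimum effective dose at all.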